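Acetyl to propanoyl: compound 3 to compound 4

The compounds below may be only part of what the source reports. "The series", "measured", "known", "first", "only" and "open" are said of these compounds alone.

Measured in an ADME assay on WI-38 cells (Homo sapiens) for inhibition, read by sulforhodamine B assay, with a stated time of 48 h; on this read-out lower numbers stand for stronger inhibition and higher numbers for weaker inhibition:
- compound 1 `CCCCCCCCCCOc1cc2c(=O)c(C(=O)NCc3ccc(F)cc3)c[nH]c2cc1OCC`: > 100000 nM (a limit)
- compound 2 `CCCCCCCCCCOc1cc2c(=O)c(C(=O)NCCOCCO)c[nH]c2cc1OCC`: 43900 nM
- compound 3 `CCCCCCCCCCOc1cc2c(=O)c(C(=O)OCC)cn(C(C)=O)c2cc1OCC`: > 100000 nM (a limit)

Compound 3 gives no number, only a limit. It sits at the limit of > 100000 nM in this assay, at which 2 of the 3 values shown sit.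

Compound 4 `CCCCCCCCCCOc1cc2c(=O)c(C(=O)OCC)cn(C(=O)CC)c2cc1OCC` differs from compound 3 by one change: methyl in place of hydrogen on a saturated chain carbon bound to a carbonyl carbon. In words, this is methyl in place of hydrogen on a saturated chain carbon bound to a carbonyl carbon, or acetyl to propanoyl.

Within the data shown here, the only measured step is an at least 2.2-fold lower number from compound 1 to compound 2 (0.35 log units; beyond the scatter). It puts (2-hydroxyethoxy)methyl in place of 4-fluorophenyl, a different group on a different part of the molecule, so it bears only weakly on this change. Among the measured compounds shown here, no step in the acyl group has been measured. No step beyond the scatter is therefore expected in this assay.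

The expected step is a number no higher from compound 3 to compound 4 (the limit leaves the size open).

Compound 4 is estimated at 100000 nM, with an expected range of 45000 nM to 200000 nM.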

Compound 4, half-maximal inhibitory concentration: > 100000 nM
Compound 4 ended at the assay's limit (the forecaster's own chance of this, stated with the estimate: 75%); the middle value sits exactly at the limit.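

Compound 3 and compound 4 both give only a limit in this assay, so the step from acetyl to propanoyl cannot be read: the limit of > 100000 nM in this assay, at which 3 of the 4 values shown sit.

The compounds shown leave open whether this change in the acyl group shifts the read-out at all, and in which direction.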